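From chloro to sulfanyl: what compound 3 may show

This account rests on a few compounds, and the source may have more. Where it says the series, first, only, none or still open, it means among the compounds named here.

Within the data shown here, in a functional assay on K562 cells (Homo sapiens) for cytotoxicity (on this read-out higher numbers stand for weaker inhibition and lower numbers for stronger inhibition), compound 1 (`CCC(CO)Nc1nc(NCc2ccccc2)c2nc(Cl)n(C(C)C)c2n1`) gives 91000 nM and stands highest of the two numbers measured so far, while compound 2 (`CCC(CO)Nc1nc(NCc2ccccc2)c2nc(Br)n(C(C)C)c2n1`) gives 27000 nM. Compound 3 (`CCC(CO)Nc1nc(NCc2ccccc2)c2nc(S)n(C(C)C)c2n1`) carries sulfanyl in place of chloro on an aromatic carbon. Among the measured compounds shown here, the only measured step at this place, bromo in place of chloro, is modest (a 3.4-fold lower number from compound 1 to compound 2 (0.53 log units; beyond the scatter)). For the measured compounds named here, no measured compound carries sulfanyl, so that step is a loose guide. In this assay a small step toward a lower number, not clearly beyond the scatter, is expected for compound 3 (a 1.5-fold lower number from compound 1 to compound 3 (0.18 log units; within the scatter)). The estimate for compound 3 is 60000 nM (expected range 20000 nM to 150000 nM).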

Compound 3, half-maximal inhibitory concentration: 154000 nM
The estimate for compound 3 lay 2.6-fold (0.41 log units) below the measured number; the measured number lies above the stated range.
By their numbers in this assay, from the lowest: compound 2; then compounds 1 and 3 (each within the scatter of the next).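

In this assay, replacing chloro with sulfanyl on this aromatic carbon adds a hydrogen-bond donor and a hydrogen-bond acceptor, yet the numbers stay within the scatter of each other (a 1.7-fold higher number from compound 1 to compound 3 (0.23 log units; within the scatter)). Sulfanyl and bromo, by contrast, are clearly separated (a 5.7-fold higher number from compound 2 to compound 3 (0.76 log units; beyond the scatter)), so among these three compounds only bromo stands apart at this position. No measurement offered here explains that difference. On these data alone, it remains open how an amine or a longer chain on this carbon would compare with bromo.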